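This account rests on a few compounds, and the source may have more. Where it says the series, first, only, none or still open, it means among the compounds named here.

Working notes on the series. Compound 1 `CCCc1nc2c(OCc3ccccc3)cccn2c1N` gives 31% in a functional assay on the whole organism with Rattus norvegicus as the target, at a dose of 40 mg/kg by the intraperitoneal route; on this read-out higher numbers stand for more inhibition at the one dose given (going by the name of the read-out) and lower numbers for less inhibition. Compound 2 `COC(=O)Nc1c(C)nc2c(OCc3ccccc3)cccn12` gives 0% in this assay, the lower of the two numbers, with compound 1 sitting higher by a gap beyond the usual scatter. Compound 3 `Cc1nc2c(OCc3ccccc3)cccn2c1N(C)C` differs from compound 2 in one place: dimethylamino in place of (methoxycarbonyl)amino on an aromatic carbon. Among the compounds with values here, no measured pair differing in a single place is available to gauge a change of this kind. The expected step of a number 15 percentage points higher from compound 2 to compound 3 (beyond the scatter) is a modest rise, not a large one. The estimate for compound 3 is 15%, within a range from 0% to 40%.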

Compound 3, a percentage reported as inhibition, in the whole organism at one dose (the size of the read-out at that dose, not a potency): 76%
The estimate for compound 3 lay 61 percentage points below the measured number; measured number above the stated range.
By their numbers in this assay, from the lowest: compound 2; then compound 1; then compound 3.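

In this assay, the position on the five-membered aromatic ring responds strongly to the group it carries: dimethylamino in place of (methoxycarbonyl)amino gives a number 76 percentage points higher from compound 2 to compound 3 (beyond the scatter) and is a large step. The change swaps a group with a carbonyl and a hydrogen-bond donor for a smaller one with neither. Nothing measured here ties the step to any one of these differences.

From the compounds shown here alone, whether a primary amine or an acetamide at this position would stand nearer compound 2 or compound 3 remains open. Going by these compounds, the effect of a longer chain in place of the methyl group on compound 3 also remains open.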